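This account rests on a few compounds, and the source may have more. Where it says the series, first, only, none or still open, it means among the compounds named here.

Measured so far: compound 1 `Nc1n[nH]c2cc(-c3ccc(=O)n(Cc4cccc(Cl)c4)c3)ccc12` gives 6 nM in an assay for inhibition of MAP kinase-interacting serine/threonine-protein kinase 2 (Homo sapiens), read by luminescence and ADP-Glo, with a stated time of 2 h; a lower number here means a stronger inhibitor, a higher number a weaker inhibitor. Compound 3 `Nc1n[nH]c2cc(-c3ccc(=O)n(Cc4cccc(C(F)(F)F)c4)c3)ccc12` gives 21 nM in this assay. Compound 2 `O=C(N1CCOCC1)n1cc(-c2ccc3cn[nH]c3c2)ccc1=O` reaches only the limit of the assay, > 2000 nM in this assay, so for compound 2 no number is known, only that it sits at the limit (the limit of > 2000 nM in this assay, at which 1 of the 3 values shown sits).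

Compound 4 `O=c1ccc(-c2ccc3cn[nH]c3c2)cn1Cc1ccccc1Cl` has not yet been measured. It differs from compound 2 in one place: 2-chlorobenzyl in place of (morpholin-4-yl)carbonyl on an aromatic nitrogen. Going by the values given here, no measured step covers this swap of a carbonyl-linked group for a benzyl group. Among the compounds with values here, the single measured step, a 3.5-fold higher number from compound 1 to compound 3 (0.54 log units; beyond the scatter), concerns only a change within a benzyl group and so bears only indirectly on it. Compounds 1 and 3, which also carry a substituted benzyl group, give low numbers, whereas compound 2 with its carbonyl-linked group gives only a limit. On that basis compound 4 is expected to move well away from the limit, toward a stronger inhibitor, so that the estimated step from compound 2 to compound 4 is an at least 20-fold lower number from compound 2 to compound 4 (1.30 log units; beyond the scatter). The estimate for compound 4 is 100 nM, within a range of 20 nM to 800 nM.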

Compound 4, half-maximal inhibitory concentration: 78 nM
The estimate for compound 4 lay 1.3-fold (0.11 log units) above the measured number; the range from low to high includes it.
By their numbers in this assay, from the lowest: compound 1; then compound 3; then compound 4. At a limit, above all of these: compound 2.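

On this aromatic nitrogen, 2-chlorobenzyl in place of (morpholin-4-yl)carbonyl brings an at least 25-fold lower number from compound 2 to compound 4 (1.40 log units; beyond the scatter) in this assay, whereas a 3.5-fold higher number from compound 1 to compound 3 (0.54 log units; beyond the scatter) only altered a substituent within a benzyl group. The group on this nitrogen can therefore separate a measurable inhibitor from one that reaches the limit, and since both groups hold the same count of heavy atoms, that count does not explain the difference. The true size of this step stays unknown because compound 2 gives only a limit, not a number: the limit of > 2000 nM in this assay, at which 1 of the 4 values shown sits.

One open question is whether the chlorine matters, which a plain benzyl or a 2-phenylethyl group on this nitrogen would test. Going by these compounds, it also remains open whether the carbonyl or the morpholine ring goes with the weak result, which a morpholin-4-ylmethyl group could help to separate.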